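The compounds below may be only part of what the source reports. "The series", "measured", "known", "first", "only" and "open" are said of these compounds alone.

Measured so far in an assay on HEK293 cells for displacement of a labelled ligand from Urotensin-2 receptor (Homo sapiens); a lower number here means a stronger inhibitor, a higher number a weaker inhibitor:
- compound 1, `CCN(CC(=O)N1CCC[C@H](c2ccccc2)[C@@H]1CN1CCCC1)c1ccc(Cl)c(Cl)c1`: 31.6 nM
- compound 2, `O=C(CN(CC1CC1)c1ccc(Cl)c(Cl)c1)N1CCC[C@H](c2ccccc2)[C@@H]1CN1CCCC1`: 50.1 nM
- compound 3, `CC(=O)N(CC(=O)N1CCC[C@H](c2ccccc2)[C@@H]1CN1CCCC1)c1ccc(Cl)c(Cl)c1`: 1580 nM

All three share one core and differ only in the group carried on the nitrogen attached to the dichlorinated aromatic ring. Compound 3 gives the highest number of the three: the step of a 50-fold higher number from compound 1 to compound 3 (1.70 log units; beyond the scatter) and the step of a 32-fold higher number from compound 2 to compound 3 (1.50 log units; beyond the scatter) are both large and beyond the scatter, whereas the step of a 1.6-fold higher number from compound 1 to compound 2 (0.20 log units; within the scatter) stays within the scatter.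

Compound 4, `CS(=O)(=O)N(CC(=O)N1CCC[C@H](c2ccccc2)[C@@H]1CN1CCCC1)c1ccc(Cl)c(Cl)c1`, differs from compound 3 in one place: methylsulfonyl in place of acetyl on a nitrogen on an aromatic ring. Among the compounds with values here, no measured pair shows this kind of exchange directly. The two steps that bear on it, from compound 1 and from compound 2 to compound 3, both show that replacing an alkyl group on this nitrogen with acetyl raises the number sharply. Compound 4 keeps a non-alkyl group there, so the expectation is a number near that of compound 3, with the step of a 1.6-fold higher number from compound 3 to compound 4 (0.20 log units; within the scatter) expected to stay close to the scatter. Compound 4 is therefore expected to give about 2500 nM in this assay, estimated between 800 nM and 8000 nM.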

Compound 4, inhibition constant: 79.4 nM
Compound 4: middle estimate off by 31-fold (1.50 log units), on the high side; measured number below the stated range.
By their numbers in this assay, from the lowest: compounds 1, 2 and 4 (each within the scatter of the next, the first and the last beyond it); then compound 3.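

Read in this assay this nitrogen on an aromatic ring proves not to penalise every non-alkyl group, since putting methylsulfonyl in place of acetyl gives a 20-fold lower number from compound 3 to compound 4 (1.30 log units; beyond the scatter) and recovers most of what acetyl lost. Set against the alkyl groups, methylsulfonyl cannot be told apart from cyclopropylmethyl in a 1.6-fold higher number from compound 2 to compound 4 (0.20 log units; within the scatter) and sits only modestly behind ethyl in a 2.5-fold higher number from compound 1 to compound 4 (0.40 log units; beyond the scatter) so the sharp loss among these four compounds is seen with acetyl alone. Nothing available here explains why two such groups on the same nitrogen part so widely.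

Still open, going by these compounds, is how far methylsulfonyl can be extended, for instance to ethylsulfonyl or phenylsulfonyl. Also open, on these data alone, is whether other carbonyl groups, such as methoxycarbonyl or benzoyl, or a bare hydrogen on this nitrogen, would behave like acetyl or like the alkyl groups.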